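From Benzyloxycarbonyl to (4-Cyanophenyl)sulfonyl on the Amine

This account rests on a few compounds, and the source may have more. Where it says the series, first, only, none or still open, it means among the compounds named here.

Three compounds of this series have been examined in an ADME assay on microsomes from liver (Mus musculus) for metabolic stability, read by LC-MS, with NADPH named in the record, with a stated time of 60 min, tested at 1 uM, in the absence of a further agent; a higher number here means that more of the compound is left, a lower number that less of the compound is left. Compound 1, `COc1ccc(-c2c(C)oc3c(N4CC[C@@H](NC(C)=O)C4)cc(C)nc23)cc1OC`, reaches the limit of the assay, which reports it as > 95%. Compound 2, `COc1ccc(-c2c(C)nc3c(N4CC[C@@H](NC(C)=O)C4)cc(C)nn23)cn1`, likewise sits at the limit, recorded as > 95%. Compound 3, `COc1ccc(-c2c(C)nc3c(N4CC[C@@H](NC(=O)OCc5ccccc5)C4)cc(C)nn23)cc1OC`, is the closest relative of the compound still to be measured, and its own result is again a limit rather than a number, given as > 95%. So far, then, the set shows no spread at all: the limit of > 95% in this assay, at which 3 of the 3 values shown sit, and no step between any two measured compounds can be read off.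

Compound 4, `COc1ccc(-c2c(C)nc3c(N4CC[C@@H](NS(=O)(=O)c5ccc(C#N)cc5)C4)cc(C)nn23)cc1OC`, differs from compound 3 in a single place. (4-cyanophenyl)sulfonyl in place of benzyloxycarbonyl on an amine nitrogen The amine nitrogen itself, attached to a saturated ring carbon, is unchanged.

With every measured value resting at the limit, the starting point is known only as a floor. The author expects the change to yield a number at least 5 percentage points lower from compound 3 to compound 4 (that floor lies within the scatter), that is, no movement beyond the usual scatter, or at most a small loss. For compound 4 the estimate is 90%, with a plausible range from 75% to 98%, and a fair chance that the assay again returns only its limit.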

Compound 4, percent of the compound remaining: > 95%
Compound 4: only a limit was reported (the forecaster's own chance of this, stated with the estimate: 55%); middle value at least 5 percentage points from the limit.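

In this assay compound 4 returns > 95%, which is a limit of the assay and not a number. Compound 3 also rests at a limit, so no step can be read between compound 3 and compound 4. The compounds shown leave open how far their stability actually differs, as all of them share one ceiling: the limit of > 95% in this assay, at which 4 of the 4 values shown sit.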